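The source may report more compounds than this note shows. Statements on the series, on what has been measured and on what is new or still open speak of the compounds shown alone.

Measured so far:
compound 1, `COc1ccc(/C=N/NC(=O)c2ccc(O[C@@H]3O[C@H](CO)[C@@H](O)[C@H](O)[C@H]3O)cc2)cc1` — 11.3%
compound 2, `CCCCCc1nnc(-c2ccc(O[C@@H]3O[C@H](COC(C)=O)[C@@H](OC(C)=O)[C@H](OC(C)=O)[C@H]3OC(C)=O)cc2)o1` — 21.5%

Both numbers come from a functional assay on MDA-MB-231 cells (Homo sapiens) for inhibition, read by MTT assay, with a stated time of 24 h, tested at 100 uM; on this read-out lower numbers stand for less inhibition and higher numbers for more inhibition at the one concentration tested (going by the name of the read-out). Compound 1 stands lowest of the two; the nearest is compound 2, whose number is higher by a gap that lies beyond the usual scatter. Among the compounds with values here, no pair of measured compounds differs in one place only, so no step size is known for any single structural change.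

Compound 3, `O=C(N/N=C/c1ccc(Cl)cc1)c1ccc(O[C@@H]2O[C@H](CO)[C@@H](O)[C@H](O)[C@H]2O)cc1`, is still to be measured. Against compound 1 it differs in one place: chloro in place of methoxy on an aromatic carbon. The rest of the shared core of compound 1 is unchanged. Nothing in the two measured numbers speaks to this particular change, so only a weak expectation can be formed. The expected change, a number 3.7 percentage points higher from compound 1 to compound 3 (within the scatter), is small and is not expected to reach clearly beyond the scatter in either direction. Compound 3 is expected to give about 15% in this assay, with a range from 4% to 30%.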

Compound 3, a percentage reported as inhibition, at one concentration (the size of the read-out at that concentration, not a potency): 2.26%
Beside the measured number, compound 3's estimate is 12.7 percentage points above it; measured number outside the range, below it.
By their numbers in this assay, from the lowest: compounds 3 and 1 (each within the scatter of the next); then compound 2.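

In this assay, the series now has its first step at a single place: chloro in place of methoxy on an aromatic carbon, para to a large group, gives a number 9 percentage points lower from compound 1 to compound 3 (within the scatter). At this position, the change from 4-methoxyphenyl to 4-chlorophenyl is therefore not resolved by this read-out, with compound 3 at 2.26% and compound 1 at 11.3% remaining within the scatter of each other. No measurement at hand offers an explanation for this step.

The compounds shown leave open whether an amine, a carboxylic acid or a longer alkoxy chain at this same position would give a step beyond the scatter. Also open, as far as these compounds go, is whether the chloro-for-methoxy step would read the same on the core of compound 2.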